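The source may report more compounds than this note shows. Statements on the series, on what has been measured and on what is new or still open speak of the compounds shown alone.

Two compounds from a series built on a shared core have been measured, and a third awaits its number. Compound 1 `[N-]=[N+]=NCC(O)Cn1c(=O)n(C2OC(CO)[C@@H](O)[C@H]2O)c2nc(N)nc(O)c21` carries a short chain on the core. In a functional assay on the whole organism (B cells) with Mus musculus as the target (on this read-out higher numbers stand for larger maximal responses and lower numbers for smaller maximal responses), compound 1 gives 91%. Compound 2 `Nc1nc(O)c2c(n1)n(C1OC(CO)[C@@H](O)[C@H]1O)c(=O)n2Cc1ccc(OCc2ccccc2)cc1` carries a much larger group at the same point of the core, and in this assay compound 2 gives 5%. Going by the values given here, of the two numbers so far, compound 2 stands lowest, and its nearest neighbour, compound 1, lies far above it, well beyond the usual scatter.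

Compound 3 `N#Cc1ccc(Cn2c(=O)n(C3OC(CO)[C@@H](O)[C@H]3O)c3nc(N)nc(O)c32)cc1` is the unmeasured member. It differs from compound 2 in one place: cyano in place of benzyloxy on an aromatic carbon. Among the compounds with values here, no pair of measured compounds that differ in a single place is available, so the size of this step cannot be read from any neighbouring pair. Within the data shown here, the only guide is that compound 2, with its large group, gives 5%, while compound 1, with a small chain, gives 91%.

Compound 3 is therefore expected to rise, with an estimated step of a number 25 percentage points higher from compound 2 to compound 3 (beyond the scatter). The estimate for compound 3 is 30%, with a range from 5% to 75%.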

Compound 3, largest response reached (reported as maximal response), in percent of the reference or control that the assay uses: 50%
Estimate against measurement, compound 3: 20 percentage points below; low and high end bracket the measured number.
By their numbers in this assay, from the lowest: compound 2; then compound 3; then compound 1.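

In this assay, cyano in place of benzyloxy on the aromatic carbon gives a number 45 percentage points higher from compound 2 to compound 3 (beyond the scatter), a large step from a change at a single place, so the maximal response depends strongly on the group held at this point of the ring. A ring of carbon attached through the saturated chain carbon is therefore compatible with a substantial response when it bears cyano, yet 4-cyanophenyl in place of 2-azido-1-hydroxyethyl still gives a number 41 percentage points lower from compound 1 to compound 3 (beyond the scatter), so this ring does not match the response seen with the short chain. Nothing available on the compounds accounts for the size of either step.

Two steps cannot show whether the response follows the size of the group on the ring or something else about it, and a small group such as methoxy or a single fluorine atom in the same place could help to separate those possibilities. On these data alone, it also remains open how an amine or a carboxylic acid at this point of the ring would compare with cyano, and whether a longer chain in place of 2-azido-1-hydroxyethyl would hold the response.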